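A few compounds are considered here, and "the series" means these few. Any claim that something is new, unique, unknown or untested is made for them only; others in the source may bear on it.

Measured so far in a functional assay on SK-OV-3 cells (Homo sapiens) for inhibition, read by CCK-8 assay, with a stated time of 70 h; on this read-out higher numbers stand for weaker inhibition and lower numbers for stronger inhibition:
- compound 1 `COc1ccc(COc2ccc(OCCOCCNC3CCCC3)cc2)cc1`: 15700 nM
- compound 2 `c1ccc2cc(OCCOCCNC3CCCC3)ccc2c1`: 40600 nM
- compound 3 `c1ccc(COc2ccc(OCCOCCNC3CCCCCC3)cc2)cc1`: 7460 nM

Compound 1 gives the second highest of the three numbers in this assay; the nearest is compound 3 with the lower number, the furthest compound 2 with the higher one, and both gaps lie beyond the usual scatter. No pair of these compounds differs in a single place, so no step has been counted among them.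

Compound 4 `O=C(O)c1ccc(COc2ccc(OCCOCCNC3CCCC3)cc2)cc1` remains to be measured in this assay. Against compound 1 it carries carboxy in place of methoxy on an aromatic carbon.

No measured step describes a change of this kind in this assay. A modest loss, expected to lie around or somewhat beyond the scatter, seems the more likely direction; the estimated step is a 1.8-fold higher number from compound 1 to compound 4 (0.25 log units; within the scatter). Compound 4 is therefore estimated at 28000 nM, within a range of 9000 nM to 90000 nM.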

Compound 4, half-maximal inhibitory concentration: > 100000 nM
Compound 4: no number, only a limit; the forecaster's own chance of this, stated with the estimate: 20%; middle value at least 3.5-fold (0.55 log units) away from the limit.
By their numbers in this assay, from the lowest: compound 3; then compound 1; then compound 2. At a limit, above all of these: compound 4.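

In this assay, the position para to a large group does not accept every replacement of methoxy: carboxy there gives an at least 6.3-fold higher number from compound 1 to compound 4 (0.80 log units; beyond the scatter). The earlier compounds shown here held no change at this position that could be read as a single step. Compound 4 carries a limit, not a number, and the full size of the step stays unread: the limit of > 100000 nM in this assay, at which 1 of the 4 values shown sits.

An ester or a primary amide at this position would show whether the loss follows the carboxylic acid alone. Going by these compounds, whether carboxy costs as much on the core of compound 3 remains open.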